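Dropping one trifluoromethyl from a bis-trifluoromethyl urea

This account rests on a few compounds, and the source may have more. Where it says the series, first, only, none or still open, it means among the compounds named here.

Measured compounds:
compound 1 `O=C(Nc1cccc(-n2cc(-c3ccncc3)c(-c3cc(O)cc(Cl)c3)n2)c1)Nc1ccc(Cl)c(Cl)c1`: -25.3%
compound 2 `COc1cc(Cl)cc(-c2nn(-c3cccc(NC(=O)Nc4cc(C(F)(F)F)cc(C(F)(F)F)c4)c3)cc2-c2ccncc2)c1`: 6.21%

Both compounds were tested in a functional assay on HCT-15 cells (Homo sapiens) for inhibition, read by sulforhodamine B assay, with a stated time of 48 h, tested at 10 uM; a higher number here means a weaker effect of the compound at the concentration tested, a lower number a stronger effect. Compound 1 gives -25.3%, and compound 2 gives 6.21%, the higher of the two numbers; the gap between them is beyond the scatter, so compound 2 shows the weaker effect of the pair at this concentration.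

Compound 3 `COc1cc(Cl)cc(-c2nn(-c3cccc(NC(=O)Nc4cccc(C(F)(F)F)c4)c3)cc2-c2ccncc2)c1` has not yet been measured. It differs from compound 2 in one place: hydrogen in place of trifluoromethyl on an aromatic carbon, on an aromatic carbon of a six-membered aromatic ring of carbon only, meta to a trifluoromethyl group. For the measured compounds named here, no step between two measured compounds describes a change of this kind, so there is nothing to anchor its size. A change this small at the edge of the molecule is expected to move the number little, with a step from compound 2 to compound 3 of about a number 3.8 percentage points higher from compound 2 to compound 3 (within the scatter), within or only just beyond the scatter. Compound 3 is therefore estimated at 10%, in a range from -20% to 40%.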

Compound 3, a percentage reported as activity, at one concentration (the size of the read-out at that concentration, not a potency): 7.83%
The estimate for compound 3 lay 2.2 percentage points above the measured number, and the stated range covers the measured number.
By their numbers in this assay, from the lowest: compound 1; then compounds 2 and 3 (each within the scatter of the next).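

Hydrogen in place of trifluoromethyl on this aromatic carbon, meta to a trifluoromethyl group, gives a number 1.6 percentage points higher from compound 2 to compound 3 (within the scatter) in this assay at the single concentration tested. For the compounds shown here, this is the first step here between two measured compounds that differ in one place, and it shows that four heavy atoms can leave this position with no readable difference in the number, so this pair does not need the second trifluoromethyl group to give this read-out. Nothing on hand explains why the number holds.

As far as these compounds go, whether other groups on this carbon, such as an amine or a carboxylic acid, would also leave the number unmoved remains open. One concentration also gives the size of the read-out rather than a potency, so the two compounds could still differ at other concentrations.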